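The compounds below may be only part of what the source reports. "The series", "measured", "known", "first", "only" and "open" are said of these compounds alone.

In an assay on CHO cells for displacement of a labelled ligand from adenosine receptor A3 (Homo sapiens), read by scintillation counting, with a stated time of 45 min, tested at 1 uM, in the presence of a further agent that is not named here (a higher number here means more inhibition at the concentration tested (going by the name of the read-out), a lower number less inhibition), compound 1 `CCCn1c(=O)[nH]c2nc(-c3ccc(S(=O)(=O)N4CCN(c5ccc(Cl)cc5F)CC4)cc3)[nH]c2c1=O` gives 14%. Compound 2 `CCCn1c(=O)[nH]c2nc(-c3ccc(S(=O)(=O)N4CCN(Cc5cccc(C)c5)CC4)cc3)[nH]c2c1=O` gives 17%, and the change a number 3 percentage points higher from compound 1 to compound 2 (within the scatter) lies within the scatter, so the two numbers cannot be told apart; compound 2 stands alongside compound 1 rather than above it. Compound 3 `CCCn1c(=O)[nH]c2nc(-c3ccc(S(=O)(=O)N4CCN(c5ccccc5Cl)CC4)cc3)[nH]c2c1=O` differs from compound 2 in one place: 2-chlorophenyl in place of 3-methylbenzyl on an amine nitrogen in a ring. Among the compounds with values here, the only step measured so far also exchanged an aryl ring and a benzyl group on this ring nitrogen, and that exchange moved the number by only a number 3 percentage points higher from compound 1 to compound 2 (within the scatter). Compound 3 again carries a halogenated phenyl ring on that nitrogen, as compound 1 does, and compound 1 gives 14%. The step to compound 3 is therefore expected to be a number 2 percentage points lower from compound 2 to compound 3 (within the scatter), not beyond the scatter. Compound 3 is estimated to give 15%, between 5% and 28%.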

Compound 3, a percentage reported as inhibition, at one concentration (the size of the read-out at that concentration, not a potency): 32%
Estimate against measurement, compound 3: 17 percentage points below; measured number above the stated range.
By their numbers in this assay, from the lowest: compounds 1 and 2 (each within the scatter of the next); then compound 3.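

Within the data shown here, putting 2-chlorophenyl in place of 3-methylbenzyl on this ring nitrogen in this assay gives a number 15 percentage points higher from compound 2 to compound 3 (beyond the scatter), the first step at this position to clear the usual scatter. A halogenated phenyl ring alone does not settle the result, as 2-chlorophenyl in place of 4-chloro-2-fluorophenyl gives a number 18 percentage points higher from compound 1 to compound 3 (beyond the scatter), so the halogens on the ring, and not only the ring itself, go with a change in the number. No independent measurement is available to explain these differences.

The compounds shown leave open whether a plain phenyl or a 2-methylphenyl group on this nitrogen would match the number of compound 3, or whether the chlorine is needed. From the compounds shown here alone, what a benzyl group carrying chlorine, or a chain ending in a carboxylic acid, would give also remains open.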